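A few compounds are considered here, and "the series" means these few. Any claim that something is new, unique, unknown or untested is made for them only; others in the source may bear on it.

Values measured so far in a functional assay on a cell-free system (plasma, Homo sapiens) for inhibition, with Plasma (Rattus norvegicus) as the target; a lower number here means a stronger inhibitor, a higher number a weaker inhibitor
- compound 1 `CCCCOc1ccc2c(N3CCNCC3)cc(=O)oc2c1C` gives 2790 nM
- compound 2 `COCOc1ccc2c(N3CCNCC3)cc(=O)oc2c1C` gives 2300 nM

Among the compounds with values here, compound 2 stands within the scatter of compound 1, the only other measured compound. Compound 3 `CSCOc1ccc2c(N3CCNCC3)cc(=O)oc2c1C` has methylsulfanyl in place of methoxy on a saturated chain carbon bound to an oxygen on an aromatic ring. Within the data shown here, the one measured step at this place, methoxy in place of propyl, stayed within the scatter (a 1.2-fold lower number from compound 1 to compound 2 (0.08 log units; within the scatter)). No step beyond the scatter is therefore expected in this assay, and the expected step is small (a 1.0-fold higher number from compound 2 to compound 3 (0.02 log units; within the scatter)). For compound 3 the estimated value is 2400 nM, with an expected range of 1000 nM to 5500 nM.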

Compound 3, half-maximal inhibitory concentration: 900 nM
Beside the measured number, compound 3's estimate is 2.7-fold (0.43 log units) above it, outside the stated range (below it).
By their numbers in this assay, from the lowest: compound 3; then compounds 2 and 1 (each within the scatter of the next).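

In this assay this position proves responsive to the group on the saturated chain carbon: methylsulfanyl in place of methoxy gives a change beyond the scatter (a 2.6-fold lower number from compound 2 to compound 3 (0.41 log units; beyond the scatter)), and methylsulfanyl in place of propyl does too (a 3.1-fold lower number from compound 1 to compound 3 (0.49 log units; beyond the scatter)). Methoxy and methylsulfanyl have the same counts of heavy atoms and hydrogen-bond acceptors, so those counts do not separate compound 2 from compound 3. Sulfur in place of oxygen is the change that accompanies the lower number here.

From the compounds shown here alone, whether ethylsulfanyl or an amine at this place would give a lower number remains open. Nothing at hand explains the step.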